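Notes on methyl in place of chloro

The source may report more compounds than this note shows. Statements on the series, on what has been measured and on what is new or still open speak of the compounds shown alone.

Compound 1: `Cn1nc(-c2ccc(F)cc2)n(C)c1=S`, 0.61 mg/kg
Compound 2: `COc1ccc(-c2nn(C)c(=S)n2C)cc1`, > 25 mg/kg (a limit)
Compound 3: `Cn1nc(-c2ccc(Cl)cc2)n(C)c1=S`, 1.34 mg/kg

All values come from a functional assay on the whole organism with Mus musculus as the target; on this read-out higher numbers stand for an effect only at larger amounts of compound and lower numbers for an effect already at smaller amounts. Compound 3 at 1.34 mg/kg has the higher of the two true numbers, and a 2.2-fold higher number from compound 1 to compound 3 (0.34 log units; beyond the scatter) separates them. Compound 2 stands at a limit, > 25 mg/kg. Compound 4 (`Cc1ccc(-c2nn(C)c(=S)n2C)cc1`) carries methyl in place of chloro on an aromatic carbon. Within the data shown here, no methyl compound has been measured, so the nearest guides are the modest 2.2-fold higher number from compound 1 to compound 3 (0.34 log units; beyond the scatter) and the large at least 18-fold lower number from compound 2 to compound 3 (1.27 log units; beyond the scatter). The large at least 40-fold higher number from compound 1 to compound 2 (1.61 log units; beyond the scatter) keeps the upper range wide. In this assay, a modest step is expected, namely a 2.2-fold higher number from compound 3 to compound 4 (0.35 log units; beyond the scatter). For compound 4 the estimated value is 3 mg/kg, with an expected range from 0.8 mg/kg to 15 mg/kg.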

Compound 4, dose for half-maximal effect: 1.74 mg/kg
Beside the measured number, compound 4's estimate is 1.7-fold (0.24 log units) above it; measured number inside the range.
By their numbers in this assay, from the lowest: compound 1; then compounds 3 and 4 (each within the scatter of the next). At a limit, above all of these: compound 2.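

At this position, on an aromatic carbon, the new compound shows that methyl and chloro cannot be told apart in this assay: a 1.3-fold higher number from compound 3 to compound 4 (0.11 log units; within the scatter). Fluoro stays separate from methyl, with a 2.9-fold higher number from compound 1 to compound 4 (0.46 log units; beyond the scatter), so compound 1 keeps the lowest number. Compound 2 stands at a limit, so an at least 14-fold lower number from compound 2 to compound 4 (1.15 log units; beyond the scatter) is a bound and not a size, and it sets methyl clearly apart from methoxy: the limit of > 25 mg/kg in this assay, at which 1 of the 4 values shown sits.

Open, from the compounds shown here alone, is how an amine, a hydroxyl or a longer chain on this carbon would read. Also open, going by these compounds, is whether the large gap belongs to methoxy alone.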